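The source may report more compounds than this note shows. Statements on the series, on what has been measured and on what is new or still open speak of the compounds shown alone.

Compound 1 `C=CC(=O)Nc1cc(Nc2nc(C)cc(-c3cn(C)c4ccccc34)n2)c(OC)cc1N(C)CCN(C)C`: 4810 nM
Compound 2 `CC/C=C\C(=O)Nc1cc(Nc2nc(C)cc(-c3cn(C)c4ccccc34)n2)c(OC)cc1N(C)CCN(C)C`: 1990 nM
Compound 3 `CCC/C=C\C(=O)Nc1cc(Nc2nc(C)cc(-c3cn(C)c4ccccc34)n2)c(OC)cc1N(C)CCN(C)C`: 254 nM

These three compounds share one core and differ only in the chain attached to the carbonyl carbon. In a functional assay on NCI-H1975 cells (Homo sapiens) for antiproliferative activity, read by MTT assay, with a stated time of 72 h (a higher number here means a weaker inhibitor, a lower number a stronger inhibitor), compound 2 gives 1990 nM, the second highest of the three numbers. Its nearest neighbour is compound 1: a 2.4-fold lower number from compound 1 to compound 2 (0.38 log units; beyond the scatter). Its furthest is compound 3: a 7.8-fold lower number from compound 2 to compound 3 (0.89 log units; beyond the scatter). Compound 4 `CC/C=C\C(=O)Nc1cc(Nc2nc(C)cc(-c3cn(C)c4ccc(F)cc34)n2)c(OC)cc1N(C)CCN(C)C` has not yet been measured. It keeps the but-1-en-1-yl chain of compound 2 and differs from it elsewhere: fluoro in place of hydrogen on an aromatic carbon. For the measured compounds named here, none of the measured steps touches this ring; all of them alter the chain on the carbonyl carbon, and even the largest of them, a 19-fold lower number from compound 1 to compound 3 (1.28 log units; beyond the scatter), tells nothing about a fluoro on the ring. Going by the values given here, with no comparable step to draw on, the expectation for compound 4 is a number close to that of compound 2, with no step beyond the scatter: a 1.0-fold higher number from compound 2 to compound 4 (0.00 log units; within the scatter). The estimate for compound 4 is 2000 nM, within a range from 700 nM to 6000 nM.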

Compound 4, half-maximal inhibitory concentration: 10400 nM
Beside the measured number, compound 4's estimate is 5.2-fold (0.72 log units) below it; measured number outside the range, above it.
By their numbers in this assay, from the lowest: compound 3; then compound 2; then compound 1; then compound 4.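

In this assay the swap of hydrogen for fluoro on an aromatic carbon gives a 5.2-fold higher number from compound 2 to compound 4 (0.72 log units; beyond the scatter) and so shows that this ring position is sensitive, since a single added heavy atom is enough to move the number. The earlier steps shown here all altered the chain on the carbonyl carbon and all lowered the number, whereas this first change on the ring raises it, meaning a weaker inhibitor. Nothing shown here explains why this fluoro has that effect.

Going by these compounds, it remains open whether a chloro, a methyl or a methoxy group on the same carbon would raise the number too, or whether hydrogen is preferred there. On these data alone, it is also open whether fluoro would have a similar effect alongside the pent-1-en-1-yl chain of compound 3.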